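Chloro for Bromo on Two Related Cores

This account rests on a few compounds, and the source may have more. Where it says the series, first, only, none or still open, it means among the compounds named here.

Compound 1 `COC(=O)[C@@]1(C)CCC=C2[C@@H]1CC[C@@H](C)[C@]2(C)Cc1c(C)[nH]c2c(Br)cccc12` and compound 2 `COC(=O)[C@@]1(C)CCC=C2[C@@H]1CC[C@@H](C)[C@]2(C)Cc1c(C)[nH]c2c(Cl)cccc12` share one core, while compound 3 `COC(=O)[C@@]1(C)CC[C@@H]2C3=C1CC[C@@H](C)[C@]3(C)Cc1c2[nH]c2c(Br)cccc12` is built on a second core; the difference between the two cores is not broken down here. In a functional assay on HeLa cells (Homo sapiens) for inhibition, read by sulforhodamine B assay, with a stated time of 48 h (a higher number here means a weaker inhibitor of growth, a lower number a stronger inhibitor of growth), compound 1 gives 22000 nM, and compound 2 gives 17000 nM. The change between them, (chloro in place of bromo on an aromatic carbon), made a step of a 1.3-fold lower number from compound 1 to compound 2 (0.11 log units; within the scatter). In this assay compound 3 gives 18000 nM. Compound 4 `COC(=O)[C@@]1(C)CC[C@@H]2C3=C1CC[C@@H](C)[C@]3(C)Cc1c2[nH]c2c(Cl)cccc12` carries the same kind of change on the second core, (chloro in place of bromo on an aromatic carbon); here the aromatic carbon belongs to a fused or bridged system of five rings rather than two. Because the earlier step of a 1.3-fold lower number from compound 1 to compound 2 (0.11 log units; within the scatter) stayed within the scatter, the step from compound 3 to compound 4 is expected to be about as small, a 1.3-fold lower number from compound 3 to compound 4 (0.11 log units; within the scatter). Compound 4 is therefore estimated at 14000 nM, with a likely range from 7000 nM to 28000 nM.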

Compound 4, concentration for 50% growth inhibition: 12000 nM
For compound 4 the middle estimate is 1.2-fold (0.07 log units) above the measured one; low and high end bracket the measured number.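

In this assay the change of chloro in place of bromo gave a 1.5-fold lower number from compound 3 to compound 4 (0.18 log units; within the scatter), and set beside the step on the other core it reads the same: the same change on two cores in this assay, a 1.3-fold lower number (0.11 log units; within the scatter) from compound 1 to compound 2 and a 1.5-fold lower number (0.18 log units; within the scatter) from compound 3 to compound 4, 1.2-fold (0.06 log units) apart, within the scatter of two such steps. On these two cores, then, the change carries over as a step too small to read. This does not show that it would stay as small on a further core, and with both steps within the scatter it sets neither halogen ahead of the other.

As far as these compounds go, all four compounds carry bromo or chloro on that aromatic carbon, and how a methoxy group or an amine there would read on either core stays open. Also open, from the compounds shown here alone, is how a carboxylic acid in place of the methyl ester would read.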